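A few compounds are considered here, and "the series" means these few. Any claim that something is new, unique, unknown or untested is made for them only; others in the source may bear on it.

Three compounds share a urea-linked aniline attached to a fused bicyclic core and have been characterised in an assay on isolated protein for inhibition of proto-oncogene tyrosine-protein kinase receptor Ret (Homo sapiens), read by 33P incorporation, with stated times of 15 min and 40 min; on this read-out lower numbers stand for stronger inhibition and higher numbers for weaker inhibition. Compound 1 `O=C(Nc1ccc(Nc2ncnc3c2OCCN3)cc1)Nc1ccc(C(F)(F)F)cc1` carries a trifluoromethylphenyl urea and gives 306 nM. Compound 2 `O=C(Nc1ccc(Nc2ncnc3c2OCCN3)cc1)Nc1cccc(-c2ccccc2)c1` instead carries a biphenyl urea. For compound 2 this assay returns only a limit, > 10000 nM, rather than a number (the limit of > 10000 nM in this assay, at which 1 of the 3 values shown sits). Compound 3 `CN1CCCOc2c(Nc3ccc(NC(=O)Nc4cc(C(C)(C)C)on4)cc3)ncnc21` pairs a tert-butyl isoxazolyl urea with a core whose seven-membered ring bears a methyl on its nitrogen; in this assay compound 3 gives 322 nM. On the numbers shown, compound 3 and compound 1 cannot be separated within the usual scatter of repeated measurements, and the remaining entry is a limit.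

Compound 4 `CC(C)(C)c1cc(NC(=O)Nc2ccc(Nc3ncnc4c3OCCCN4)cc2)no1` is the next step: hydrogen in place of methyl on a nitrogen on an aromatic ring in a ring. Among the compounds with values here, no pair of measured compounds differing only in this way is available, so the direction of the step is open. Given that compound 3 gives 322 nM, the change is expected to leave potency close to where it is, with the step from compound 3 to compound 4 estimated at a 1.3-fold lower number from compound 3 to compound 4 (0.11 log units; within the scatter) and unlikely to exceed the scatter. Compound 4 is therefore expected to give about 250 nM, within a range from 80 nM to 1000 nM.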

Compound 4, half-maximal inhibitory concentration: 10 nM
Estimate against measurement, compound 4: 25-fold (1.40 log units) above; the measured number lies below the stated range.
By their numbers in this assay, from the lowest: compound 4; then compounds 1 and 3 (each within the scatter of the next). At a limit, above all of these: compound 2.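

On the nitrogen of the seven-membered non-aromatic ring, three ring bonds from the ring oxygen, hydrogen in place of methyl gives a 32-fold lower number from compound 3 to compound 4 (1.51 log units; beyond the scatter) in this assay, a large step for the loss of a single carbon, and it shows that this position is far from indifferent to what it carries. The earlier compounds shown here held no pair differing in one place, so none of them could show how much turned on this nitrogen, and the value of compound 3 alone gave no sign that the methyl stood at such a sensitive place. Nothing given here speaks to what lies behind the step.

On these data alone, this is a single step, read on the tert-butyl isoxazolyl urea alone, so it remains open whether hydrogen in place of methyl does the same with another urea, such as the trifluoromethylphenyl urea of compound 1. As far as these compounds go, it also remains open where an ethyl or an acetyl group on this nitrogen would fall, and so whether any group larger than hydrogen is tolerated there.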